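Benzoxazole sulfonamides: cytotoxicity after removing one chloro

A few compounds are considered here, and "the series" means these few. Any claim that something is new, unique, unknown or untested is made for them only; others in the source may bear on it.

Measured so far in an ADME assay on HEK293 cells (Homo sapiens) for cytotoxicity, read by resazurin assay, with a stated time of 48 h; on this read-out higher numbers stand for lower toxicity in this test and lower numbers for higher toxicity in this test:
compound 1 `O=S(=O)(Nc1ccc2oc(-c3ccccc3)nc2c1)c1ccc(Cl)c(Cl)c1` gives 71000 nM
compound 2 `CCc1ccc(S(=O)(=O)Nc2ccc(-c3nc4ccccc4o3)cc2)cc1` gives 82000 nM
compound 3 `O=S(=O)(Nc1ccc(-c2nc3ccccc3o2)cc1)c1ccc(F)cc1` gives a limit of the assay, > 100000 nM

Compound 1 holds the lowest of the two numbers, and compound 2 sits within the scatter of it. Compound 4 `O=S(=O)(Nc1ccc2oc(-c3ccccc3)nc2c1)c1ccc(Cl)cc1` differs from compound 1 by hydrogen in place of chloro on an aromatic carbon; the same difference, cut one bond further out, reads 3,4-dichlorophenyl to 4-chlorophenyl. For the measured compounds named here, the one measured step that exchanges a group on an aromatic carbon is an at least 1.2-fold higher number from compound 2 to compound 3 (0.08 log units; that floor lies within the scatter); it ends at the limit described by the limit of > 100000 nM in this assay, at which 1 of the 3 values shown sits, and so sets only a floor, pointing, if anywhere, toward higher numbers. For compound 4 a step of a 1.3-fold higher number from compound 1 to compound 4 (0.10 log units; within the scatter) is therefore expected, small and possibly reaching the limit. The estimate for compound 4 is 90000 nM, between 50000 nM and 160000 nM.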

Compound 4, half-maximal cytotoxic concentration: 65000 nM
Estimate against measurement, compound 4: 1.4-fold (0.14 log units) above; low and high end bracket the measured number.
By their numbers in this assay, from the lowest: compounds 4, 1 and 2 (each within the scatter of the next). At a limit, above all of these: compound 3.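

In this assay, going from 3,4-dichlorophenyl to 4-chlorophenyl gives a 1.1-fold lower number from compound 1 to compound 4 (0.04 log units; within the scatter). This is the only step shown with a number at both ends, and it shows that this chloro, ortho to a chloro group and meta to a large group, can be replaced by hydrogen without a change beyond the scatter. Compound 3 alone holds a limit: the limit of > 100000 nM in this assay, at which 1 of the 4 values shown sits.

Open, going by these compounds, is whether an amine or a carboxylic acid at this same place would shift the number beyond the scatter. Also open, on these data alone, is what replacing the remaining chloro with hydrogen would do.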